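Notes on a shared-core series: removing the aryl carboxylic acid

The compounds below may be only part of what the source reports. "The series", "measured", "known", "first", "only" and "open" are said of these compounds alone.

Measured compounds:
compound 1 `COc1ccc(C(=O)O)cc1OC[C@H](C)COc1ccc(C(=O)CC(C)(C)C)c(O)c1C` — 384 nM
compound 2 `Cc1cc(C(=O)O)ccc1OC[C@H](C)COc1ccc(C(=O)CC(C)(C)C)c(O)c1C` — 1520 nM
compound 3 `Cc1cc(OC[C@H](C)COc2ccc(C(=O)CC(C)(C)C)c(O)c2C)ccc1C(=O)O` — 1350 nM

In an assay for positive allosteric modulation of metabotropic glutamate receptor 3 (Rattus norvegicus) (on this read-out lower numbers stand for an effect already at smaller amounts and higher numbers for an effect only at larger amounts of compound), compound 3 gives 1350 nM, the second highest of the three numbers. Its nearest neighbour is compound 2, and the step of a 1.1-fold lower number from compound 2 to compound 3 (0.05 log units; within the scatter) lies within the scatter. Compound 1 lies furthest away, with a lower number beyond the scatter.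

Compound 4 `COc1ccccc1OC[C@H](C)COc1ccc(C(=O)CC(C)(C)C)c(O)c1C` has not yet been measured. The change from compound 3 is 2-methoxyphenyl in place of 4-carboxy-3-methylphenyl on an oxygen on a saturated carbon. Within the data shown here, only one measured step touches this ring, a 1.1-fold lower number from compound 2 to compound 3 (0.05 log units; within the scatter), and it moves only the methyl group while the carboxylic acid stays; no measured pair removes the carboxylic acid, so its weight is unknown. Compound 1 carries a methoxy group on that ring in addition to the acid and gives 384 nM; this can only hint that a methoxy group is tolerated, not what losing the acid does.

With the acid present in every measured compound, the expected step of a 1.3-fold higher number from compound 3 to compound 4 (0.12 log units; within the scatter) is uncertain and a modest rise in the number is assumed. Compound 4 is therefore estimated at 1800 nM, with a range from 400 nM to 8000 nM.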

Compound 4, half-maximal effective concentration: "not active" (no number reported)
The entry for compound 4 holds no number; no gap can be computed for the estimate.
By their numbers in this assay, from the lowest: compound 1; then compounds 3 and 2 (each within the scatter of the next).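

In this assay, among these compounds, compound 4 is reported as "not active" without a number, and no step to compound 3 or to any other compound can be read from it. No supporting data bear on this result. The compounds shown leave open what removing the carboxylic acid alone does, since every compound with a number retains it.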